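This account rests on a few compounds, and the source may have more. Where it says the series, first, only, none or still open, it means among the compounds named here.

Working notes on the furan-carboxamide series.

Compound 1 `COc1ccc(-c2ccc(Cl)cc2)c2cc(C(=O)Nc3ccc(Cn4ccnc4)cc3)oc12` is the starting point of the step followed here; in a functional assay on the whole organism for inhibition, with Mus musculus as the target, at a dose of 10 mg/kg by the oral route (a lower number here means less inhibition, a higher number more inhibition at the dose given (going by the name of the read-out)), compound 1 gives "not determined" (no result reported), so it stands on no number. For the measured compounds named here, the only compound of the set with a value is compound 2 `COC(=O)Nc1cc2c(-c3ccccc3)ccc(OC)c2o1`, which in this assay gives 86%. Compound 3 `CCOC(=O)c1ccc(-c2ccc(OC)c3oc(C(=O)Nc4ccccc4)cc23)cc1` likewise gives "not determined" (no result reported) in this assay. Going by the values given here, no step between two measured compounds exists in this set, so nothing is known about how a change on the core shifts the read-out.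

Compound 4 `COC(=O)c1ccc(OC)c2oc(C(=O)Nc3ccc(Cn4ccnc4)cc3)cc12` has not yet been measured. It differs from compound 1 by methoxycarbonyl in place of 4-chlorophenyl on an aromatic carbon.

Among the compounds with values here, with compound 1 carrying no number, the size and direction of the step from compound 1 to compound 4 in this assay cannot be anchored; the expectation is a step of unknown direction, possibly no larger than the scatter, and the estimate below rests on the single value of compound 2 and on the shared core alone. Compound 4 is expected to give about 55% in this assay, with a range from 15% to 90%, the wide range reflecting that compound 2 gives 86% with a different side chain and no other value is available.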

Compound 4, a percentage reported as inhibition, in the whole organism at one dose (the size of the read-out at that dose, not a potency): 0%
Estimate against measurement, compound 4: 55 percentage points above; measured number below the stated range.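

In this assay, for the compounds shown here, compound 4 gives 0% and compound 1 gives "not determined" (no result reported) so no step from compound 1 to compound 4 can be read. The compounds shown leave open whether methoxycarbonyl in place of 4-chlorophenyl shifts the read-out, and in which direction. No available evidence bears on this result.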